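Swapping the sulfonyl aryl group in a tracheal antagonist series

A few compounds are considered here, and "the series" means these few. Any claim that something is new, unique, unknown or untested is made for them only; others in the source may bear on it.

Of the compounds shown here, three have been measured in a functional assay (trachea) for antagonist activity, with Cavia porcellus as the target; a lower number here means a less potent compound, a higher number a more potent compound, by a factor of ten per unit of this negative logarithm. Compound 1 `COc1cc(-c2nn[nH]n2)ccc1Cn1ncc2ccc(NC(=O)OC3CCCC3)cc21` gives 7.7. Compound 2 `CCCCOC(=O)Nc1ccc2cnn(Cc3ccc(C(=O)NS(=O)(=O)c4ccccc4)cc3OC)c2c1` gives 9.2. Compound 3 `COc1cc(C(=O)NS(=O)(=O)c2ccccc2Cl)ccc1Cn1ccc2ccc(NC(=O)CC3CCCC3)cc21` gives 9.8, the highest of the three numbers: its gap to compound 2 is beyond the scatter, and its gap to compound 1 is larger still. No pair among these three differs in only one place, so no single change can be read off from them directly.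

Compound 4 `COc1cc(C(=O)NS(=O)(=O)c2ccccn2)ccc1Cn1ccc2ccc(NC(=O)CC3CCCC3)cc21` has not yet been measured in this assay. It differs from compound 3 in one place: pyridin-2-yl in place of 2-chlorophenyl on a sulfonyl sulfur. The rest of the molecule, including the cyclopentylacetamide and the methoxy-bearing benzylic linker, is unchanged. Within the data shown here, there is no measured pair here showing the effect of this particular exchange. Because compound 3 sits at 9.8, and such a change on an aromatic ring at the edge of the molecule is usually modest, a small downward step of a number 0.40 log units lower from compound 3 to compound 4 (beyond the scatter) is expected, close to the scatter. Compound 4 is therefore estimated at 9.4, with a range from 8.8 to 10.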

Compound 4, negative logarithm of the antagonist equilibrium constant: 8.9
The estimate for compound 4 lay 0.50 log units above the measured number; measured number inside the range.
By their numbers in this assay, from the lowest: compound 1; then compounds 4 and 2 (each within the scatter of the next); then compound 3.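

In this assay, among these compounds, pyridin-2-yl in place of 2-chlorophenyl on a sulfonyl sulfur gives a number 0.90 log units lower from compound 3 to compound 4 (beyond the scatter) and is the first change here that can be read on its own. The earlier compounds shown here differed in several places at once, whereas this pair shows that the group on the sulfonyl sulfur alone can move the number beyond the scatter, with the cyclopentylacetamide and the rest of the molecule unchanged. Nothing shown here offers a measured explanation for the fall.

As far as these compounds go, the exchange removes a chlorine and brings in a ring nitrogen together, so the share of each remains unknown. A plain phenyl group on the sulfonyl sulfur of this same molecule would separate the two, and a 2-methylphenyl group would test whether chlorine itself is needed.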